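The compounds below may be only part of what the source reports. "The series", "measured", "known", "first", "only" and "open" are said of these compounds alone.

Working notes on the series. Three compounds sharing one core have been run in a functional assay on SGC-7901 cells (Homo sapiens) for antiproliferative activity, read by MTT assay, with a stated time of 72 h; a higher number here means a weaker inhibitor, a lower number a stronger inhibitor. Compound 1 `COc1cc(-n2cnc3ccc(-c4cccc(F)c4)cc32)cc(OC)c1OC` gives 2490 nM. Compound 2 `COc1cc(-n2cnc3ccc(-c4ccccc4)cc32)cc(OC)c1OC` gives 290 nM. Compound 3 `COc1cc(-n2cnc3ccc(-c4cccc(C)c4)cc32)cc(OC)c1OC` gives 1240 nM. Among these three numbers compound 3 holds the second highest; one gap is a 2.0-fold lower number from compound 1 to compound 3 (0.30 log units; within the scatter), and the other is a 4.3-fold higher number from compound 2 to compound 3 (0.63 log units; beyond the scatter), the latter being the only step touching compound 3 that is clearly resolved. For context, an 8.6-fold lower number from compound 1 to compound 2 (0.93 log units; beyond the scatter) is the largest step seen so far.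

Compound 4 `CCOc1ccc(-c2ccc3ncn(-c4cc(OC)c(OC)c(OC)c4)c3c2)cc1` has not yet been measured. Relative to compound 3 the change is 4-ethoxyphenyl in place of 3-methylphenyl on an aromatic carbon. Among the compounds with values here, no measured step covers a 4-ethoxyphenyl group, so the only bearing comes from a 4.3-fold higher number from compound 2 to compound 3 (0.63 log units; beyond the scatter), which shows that removing the methyl from the 3-methylphenyl of compound 3 returned a lower number in compound 2; the entering group, with its one hydrogen-bond acceptor, is untested, so the direction of its own contribution is open. The expectation is therefore a modest step, a 1.8-fold lower number from compound 3 to compound 4 (0.25 log units; within the scatter), leaning lower, with wide uncertainty. For compound 4 the estimate in this assay is 700 nM, with a range of 150 nM to 3500 nM.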

Compound 4, half-maximal inhibitory concentration: 2970 nM
Estimate against measurement, compound 4: 4.2-fold (0.63 log units) below; the range from low to high includes it.
By their numbers in this assay, from the lowest: compound 2; then compounds 3, 1 and 4 (each within the scatter of the next, the first and the last beyond it).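

In this assay the step from hydrogen to ethoxy is large, a 10-fold higher number from compound 2 to compound 4 (1.01 log units; beyond the scatter) and this places a third substituted compound clearly above compound 2, so among the four compounds shown, every group added to the phenyl ring goes with a higher number than hydrogen, and none goes against this. Replacing the 3-methylphenyl group with the 4-ethoxyphenyl group gives a 2.4-fold higher number from compound 3 to compound 4 (0.38 log units; beyond the scatter) and so resolves a change at this position, while replacing the 3-fluorophenyl group with the 4-ethoxyphenyl group gives a 1.2-fold higher number from compound 1 to compound 4 (0.08 log units; within the scatter) and leaves those two compounds unseparated. A group with a hydrogen-bond acceptor therefore does not return the number to that of compound 2, and since the step from compound 3 changes both the substituent and its place on the ring, the two contributions cannot be separated.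

Open, as far as these compounds go, is whether a methoxy, a hydroxyl or an amine on that phenyl ring would stay with the higher numbers, and whether a 3-ethoxyphenyl group would read like the 4-ethoxyphenyl group. No evidence at hand accounts for any of these steps.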